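The compounds below may be only part of what the source reports. "The series", "measured", "known", "first", "only" and "open" are said of these compounds alone.

Compound 1 `C=CCOc1ccc(C(=O)Nc2cccc(Br)n2)cc1` gives 65500 nM in an in vitro assay on HEK-tsA201 cells for antagonist activity at Neuronal acetylcholine receptor; alpha3/beta4 (Homo sapiens), read by fluorescence and calcium flux; a higher number here means a weaker inhibitor, a lower number a stronger inhibitor.
Compound 2 `C=CCOc1ccc(C(=O)Nc2cccc(CC)n2)cc1` gives 27400 nM in this assay.
Compound 3 `C=CCOc1ccc(C(=O)Nc2cccc(NCCC)n2)cc1` gives 11700 nM in this assay.

Compound 3 stands lowest of the three numbers. The measured steps are a 2.4-fold lower number from compound 1 to compound 2 (0.38 log units; beyond the scatter), a 5.6-fold lower number from compound 1 to compound 3 (0.75 log units; beyond the scatter) and a 2.3-fold lower number from compound 2 to compound 3 (0.37 log units; beyond the scatter); each of them exchanges the whole group on one aromatic carbon of the shared core for a different group. Compound 4 `C=CCOc1ccc(C(=O)Nc2cccc(NCCCC)n2)cc1` differs from compound 3 by methyl in place of hydrogen on a saturated chain carbon, three bonds along the chain from a nitrogen on an aromatic ring, so the propylamino group of compound 3 becomes a butylamino group. None of the three measured steps bears directly on this change: they replace one group with another, whereas here the group already present is only extended along its chain. The measured steps show that the group on this carbon matters, but they give no guide to the direction of a chain extension. Compound 4 is therefore expected to sit close to compound 3, with an estimated step of a 1.3-fold lower number from compound 3 to compound 4 (0.11 log units; within the scatter) that may well lie within the usual scatter. The estimate for compound 4 in this assay is 9000 nM, with a range from 4000 nM to 22000 nM.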

Compound 4, half-maximal inhibitory concentration: 19200 nM
Estimate against measurement, compound 4: 2.1-fold (0.33 log units) below; low and high end bracket the measured number.
By their numbers in this assay, from the lowest: compounds 3, 4 and 2 (each within the scatter of the next, the first and the last beyond it); then compound 1.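

Extending the propylamino group of compound 3 to the butylamino group of compound 4 gives a 1.6-fold higher number from compound 3 to compound 4 (0.22 log units; within the scatter) in this assay and so resolves no change from this added methyl. The butylamino group also gives a 1.4-fold lower number from compound 2 to compound 4 (0.15 log units; within the scatter) when set against ethyl, so compound 4 cannot be told apart from compound 2, although the propylamino group of compound 3 did stand apart from it. Set against bromo, the butylamino group still gives a 3.4-fold lower number from compound 1 to compound 4 (0.53 log units; beyond the scatter) and this remains a modest step beyond the scatter.

The compounds shown leave open whether a pentylamino group or a longer chain would keep the number in this range. They also leave open whether a propoxy group would match the propylamino group at this position. Nothing measured here accounts for these steps.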